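Cyclohexyl to oxolanyl on the ring amine

The source may report more compounds than this note shows. Statements on the series, on what has been measured and on what is new or still open speak of the compounds shown alone.

Compound 2 `COc1cccc(-n2cc3nc(-c4cccnc4C)n(C[C@H]4CCCN(CC5CCCCC5)C4)c(=O)c3n2)c1` gives the highest number of the three measured in an assay on HEK293 cells for displacement of a labelled ligand from growth hormone secretagogue receptor type 1 (Homo sapiens), with a stated time of 60 min (on this read-out higher numbers stand for weaker inhibition and lower numbers for stronger inhibition), at 200 nM. Compound 1 `COc1ccc(-n2cc3nc(-c4cccnc4C)n(C[C@H]4CCCN(C[C@H]5CCCO5)C4)c(=O)c3n2)cc1` gives 52 nM, and compound 3 `Cc1ncccc1-c1nc2cn(-c3cccc(OC(F)F)c3)nc2c(=O)n1C[C@H]1CCCN(C[C@H]2CCCO2)C1` gives 27 nM; both carry an oxolane where compound 2 carries cyclohexyl, yet both also differ from compound 2 in the group on the aromatic nitrogen. Among the measured compounds shown here, the single measured step, a 1.9-fold lower number from compound 1 to compound 3 (0.28 log units; within the scatter), changes only that group and does not bear on the amine substituent. Compound 4 `COc1cccc(-n2cc3nc(-c4cccnc4C)n(C[C@H]4CCCN(CC5CCOC5)C4)c(=O)c3n2)c1` differs from compound 2 by oxolan-3-yl in place of cyclohexyl on a saturated chain carbon bound to an amine nitrogen in a ring. For the measured compounds named here, no measured step covers this change directly; the two oxolane-bearing compounds give lower numbers than compound 2, with the other difference unresolved. For compound 4 a moderately lower number is expected, the step being a 2.5-fold lower number from compound 2 to compound 4 (0.40 log units; beyond the scatter). Compound 4 is estimated at 80 nM, between 30 nM and 220 nM.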

Compound 4, half-maximal inhibitory concentration: 60 nM
Estimate against measurement, compound 4: 1.3-fold (0.12 log units) above, within the range that was stated.
By their numbers in this assay, from the lowest: compounds 3, 1 and 4 (each within the scatter of the next, the first and the last beyond it); then compound 2.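

In this assay, replacing cyclohexyl with oxolan-3-yl on the saturated chain carbon gives a 3.3-fold lower number from compound 2 to compound 4 (0.52 log units; beyond the scatter) with the group on the aromatic nitrogen held fixed. Among the compounds shown here, the earlier oxolane compounds differed from compound 2 in that group as well, so this is the first direct reading of the amine substituent. Nothing on hand explains the step.

The ring oxygen and the smaller ring enter together here, so their shares of the step remain unresolved. Cyclopentyl or oxan-4-yl at this place would separate them.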